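Replacing a methoxybenzyl ether with a methylbenzyl ether

The compounds below may be only part of what the source reports. "The series", "measured", "known", "first", "only" and "open" are said of these compounds alone.

Compound 2 `COc1ccccc1COc1ccc(Br)cc1Cn1nc(C(=O)O)cc1C` gives 69.2 nM in a functional assay on CHO-K1 cells for antagonist activity at prostaglandin E2 receptor EP1 subtype (Homo sapiens), read by FLIPR (on this read-out higher numbers stand for weaker inhibition and lower numbers for stronger inhibition), the higher of the two numbers measured, while compound 1 `Cc1cc(C(=O)O)nn1Cc1cc(Br)ccc1OCc1ccccc1` gives 15.1 nM. Compound 3 `Cc1cccc(COc2ccc(Br)cc2Cn2nc(C(=O)O)cc2C)c1` carries 3-methylphenyl in place of 2-methoxyphenyl on a saturated chain carbon bound to an oxygen on an aromatic ring. Among the compounds with values here, the only measured step, a 4.6-fold higher number from compound 1 to compound 2 (0.66 log units; beyond the scatter), concerns adding methoxy to the unsubstituted benzyl group; no step tests a methyl. Removing that methoxy points back toward compound 1, so a lower number is expected for compound 3, with a 2.8-fold lower number from compound 2 to compound 3 (0.44 log units; beyond the scatter), giving an estimate of 25 nM and a range of 8 nM to 80 nM.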

Compound 3, inhibition constant: 525 nM
Beside the measured number, compound 3's estimate is 21-fold (1.32 log units) below it; the measured number lies above the stated range.
By their numbers in this assay, from the lowest: compound 1; then compound 2; then compound 3.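

In this assay the methyl group costs more than the methoxy group did, with a 35-fold higher number from compound 1 to compound 3 (1.54 log units; beyond the scatter) on the unsubstituted benzyl group. There is also a 7.6-fold higher number from compound 2 to compound 3 (0.88 log units; beyond the scatter) so that, among these three compounds, a substituent on the benzyl ring raises the number each time and removing the methoxy oxygen does not restore the level of compound 1. Nothing shown here accounts for the size of these steps.

Group identity and ring position change together from compound 2 to compound 3, so the compounds shown leave open which of the two drives the step. A 2-methylphenyl or a 3-methoxyphenyl group would separate them.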